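Swapping a naphthalene for a tolyl group on the pyrazole nitrogen

The source may report more compounds than this note shows. Statements on the series, on what has been measured and on what is new or still open speak of the compounds shown alone.

Compound 1 `Cc1cc(Nc2cc(-c3ccccc3)[nH]n2)n2nc(SCCCc3ccccc3)nc2n1`: 40200 nM
Compound 2 `Cc1cc(Nc2ccn(Cc3cccc4ccccc34)n2)n2nc(SCc3ccc(Br)cc3)nc2n1`: 30000 nM
Compound 3 `Cc1cc(Nc2cc(-c3ccccc3)[nH]n2)n2nc(SCc3ccc(Cl)cc3)nc2n1`: 31800 nM

In an ADME assay on GES1 cells (Homo sapiens) for inhibition, read by MTT assay, with a stated time of 72 h (on this read-out higher numbers stand for weaker inhibition and lower numbers for stronger inhibition), compound 2 gives 30000 nM, a number that sits within the usual scatter of both compound 3 and compound 1, so the three measured compounds cannot be told apart on this read-out. Compound 4 `Cc1ccc(Cn2ccc(Nc3cc(C)nc4nc(SCc5ccc(Br)cc5)nn34)n2)cc1` differs from compound 2 by 4-methylphenyl in place of naphthalen-1-yl on a saturated chain carbon bound to an aromatic nitrogen. For the measured compounds named here, the only measured step, a 1.3-fold lower number from compound 1 to compound 3 (0.10 log units; within the scatter), alters the group on the sulfur side and stays within the scatter; no measured pair changes the group on the carbon bound to the aromatic nitrogen. With nothing pointing either way, compound 4 is expected to land near compound 2, a step of no change at the digits printed from compound 2 to compound 4 (within the scatter). The estimate for compound 4 is 30000 nM, with a range from 15000 nM to 60000 nM.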

Compound 4, half-maximal inhibitory concentration: > 50000 nM
Compound 4: no number, only a limit; the forecaster's own chance of this, stated with the estimate: 15%; middle value at least 1.6-fold (0.22 log units) away from the limit.
By their numbers in this assay, from the lowest: compounds 2, 3 and 1 (each within the scatter of the next). At a limit, above all of these: compound 4.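

In this assay, compound 4 gives a limit of the assay, not a number: the limit of > 50000 nM in this assay, at which 1 of the 4 values shown sits. This is the first change shown on the saturated chain carbon bound to an aromatic nitrogen, and it reads as an at least 1.6-fold higher number from compound 2 to compound 4 (0.22 log units; that floor lies within the scatter). Going from (naphthalen-1-yl)methyl to 4-methylbenzyl therefore does not lower the number, but only a floor for the step is known, and that floor cannot be separated from the scatter.

Still open, as far as these compounds go, is how far the true value of compound 4 lies past its limit. Also open, from the compounds shown here alone, is whether an amine or a carboxylic acid in place of the methyl of 4-methylbenzyl would move the number beyond the scatter.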